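The compounds below may be only part of what the source reports. "The series", "measured", "known", "first", "only" and "open" are said of these compounds alone.

In an ADME assay on HepG2 cells (Homo sapiens) for cytotoxicity, read by MTT assay, with a stated time of 72 h (on this read-out higher numbers stand for lower toxicity in this test and lower numbers for higher toxicity in this test), compound 1 (`Cc1ccc(-c2cc3nc(N)[nH]c(=O)c3s2)cc1`) gives "nd(insoluble)" (no result reported), so it offers no number for comparison. Compound 2 (`CCCCCNc1nc2cc(-c3ccc(C)cc3)sc2c(=O)[nH]1`) gives 4200 nM and compound 3 (`CCCCCCCNc1nc2cc(-c3ccc(C)cc3)sc2c(=O)[nH]1`) gives 6800 nM. For the measured compounds named here, these are the only two numbers, and they do not separate: the one measured step, a 1.6-fold higher number from compound 2 to compound 3 (0.21 log units; within the scatter), stays within the scatter, so compound 3 stands level with compound 2.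

The next compound is compound 4 (`CCC(CC)Nc1nc2cc(-c3ccc(C)cc3)sc2c(=O)[nH]1`), with pentan-3-yl in place of heptyl on a nitrogen on an aromatic ring. Going by the values given here, no measured compound carries pentan-3-yl, so the evidence is indirect and rests on a single change to the chain on that nitrogen. With that change measured at a 1.6-fold higher number from compound 2 to compound 3 (0.21 log units; within the scatter), no step beyond the scatter is expected in this assay, and the data assign no direction. The expected shift is only a 1.3-fold lower number from compound 3 to compound 4 (0.11 log units; within the scatter), which stays inside the scatter. Compound 4 is estimated at 5300 nM, with an expected range of 2300 nM to 12000 nM.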

Compound 4, half-maximal cytotoxic concentration: 101000 nM
Estimate against measurement, compound 4: 19-fold (1.28 log units) below; measured number above the stated range.
By their numbers in this assay, from the lowest: compounds 2 and 3 (each within the scatter of the next); then compound 4.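

In this assay, the group on a nitrogen on an aromatic ring can move the number well beyond the scatter, towards lower toxicity in this test (a 15-fold higher number from compound 3 to compound 4 (1.17 log units; beyond the scatter); a 24-fold higher number from compound 2 to compound 4 (1.38 log units; beyond the scatter)). The two straight chains, pentyl and heptyl, had stayed level, so among these three compounds the change that counts is the one to pentan-3-yl, not the one between the straight chains. Nothing shown here accounts for the size of these steps.

From the compounds shown here alone, it remains open whether this shift belongs to branched chains generally or to pentan-3-yl alone; isopropyl or a ring such as cyclopentyl on the same nitrogen would help to separate the two. Also open, going by these compounds, is how a chain ending in an amine or a carboxylic acid would behave at this position.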